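A Fluorine Added to a Thiosemicarbazone Aryl Ether

The source may report more compounds than this note shows. Statements on the series, on what has been measured and on what is new or still open speak of the compounds shown alone.

Compound 1 `S=C(N/N=C/c1ccc(Oc2ccc(Cl)cc2)cc1)Nc1ccccc1` stands highest of the two measured compounds: in a physicochemical assay for lipophilicity, in phosphate buffer, measured as octanol-water partition, with a stated time of 24 h (on this read-out lower numbers stand for lower lipophilicity and higher numbers for higher lipophilicity), compound 1 gives 5.52. Its nearest neighbour, compound 2 `S=C(N/N=C/c1ccc(Oc2ccccc2)cc1)Nc1ccccc1`, differs only by hydrogen in place of chloro on an aromatic carbon; in this assay compound 2 gives 4.9, and the step of a number 0.62 log units lower from compound 1 to compound 2 (beyond the scatter) is modest but real.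

Compound 3 `Fc1ccc(NC(=S)N/N=C/c2ccc(Oc3ccc(Cl)cc3)cc2)cc1` has not yet been measured. Compared with compound 1 it carries fluoro in place of hydrogen on an aromatic carbon on an aromatic carbon of a six-membered aromatic ring of carbon only, para to a large group. Within the data shown here, the only measured step that bears on this change is the one on the other ring, and a small rise is expected for compound 3 because a number 0.62 log units lower from compound 1 to compound 2 (beyond the scatter) showed the number falling when a halogen left; fluoro brings in just one fluorine, so the expected step of a number 0.18 log units higher from compound 1 to compound 3 (within the scatter) is likely to sit within the scatter. Compound 3 is therefore estimated to give 5.7, probably between 5.4 and 6.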

Compound 3, partition coefficient: 5.78
For compound 3 the middle estimate is 0.08 log units below the measured one; low and high end bracket the measured number.
By their numbers in this assay, from the lowest: compound 2; then compounds 1 and 3 (each within the scatter of the next).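

Turning the anilino group into (4-fluorophenyl)amino gives a number 0.26 log units higher from compound 1 to compound 3 (within the scatter) in this assay, so at this position the swap of hydrogen for fluoro cannot be told apart from the ordinary spread of repeat measurements. The earlier step, a number 0.62 log units lower from compound 1 to compound 2 (beyond the scatter), involved chloro on the other ring and lay beyond the scatter, whereas this first change on the anilino side does not, so a single fluorine here leaves the reading effectively unresolved. Nothing measured here offers an explanation for the size of this step.

The compounds shown pair fluoro only with chloro on the other ring, so whether it would read the same in compound 2 remains open. On these data alone, how an amine, a carboxylic acid or a longer chain at this position would read in this assay also remains open.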